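The source may report more compounds than this note shows. Statements on the series, on what has been measured and on what is new or still open speak of the compounds shown alone.

In a functional assay on A2780 cells (Homo sapiens) for cytotoxicity (a higher number here means a weaker inhibitor, a lower number a stronger inhibitor), compound 1 (`Oc1cc(O)cc(CCCCCCCCC/C=C\CCCCCCCCCc2cc(O)cc(O)c2)c1`) gives 10.2 ug/mL, compound 2 (`Oc1cc(O)cc(CCCCC/C=C\CCCCCCCc2cc(O)cc(O)c2)c1`) gives 9.8 ug/mL and compound 3 (`Oc1cc(O)cc(CCCCCCC/C=C\CCCCCCCCCc2cc(O)cc(O)c2)c1`) gives 9.4 ug/mL, so compound 3 stands within the scatter of both others. Compound 4 (`Oc1cc(O)cc(CCCCCCC/C=C\CCCCCCCc2cc(O)cc(O)c2)c1`) differs from compound 3 by one change: 3,5-dihydroxyphenyl in place of 2-(3,5-dihydroxyphenyl)ethyl on a saturated chain carbon, seven bonds along the chain from a double-bonded chain carbon. The same exchange, 3,5-dihydroxyphenyl in place of 2-(3,5-dihydroxyphenyl)ethyl, has been measured once, as a 1.1-fold lower number from compound 1 to compound 3 (0.04 log units; within the scatter), and that step stays within the scatter. No step beyond the scatter, in either direction, is therefore expected in this assay. The estimate amounts to a 1.0-fold lower number from compound 3 to compound 4 (0.00 log units; within the scatter), an expected step of no real size. For compound 4 the expected value is 9.3 ug/mL, with an estimated range from 6.5 ug/mL to 13.5 ug/mL.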

Compound 4, half-maximal inhibitory concentration: 10.2 ug/mL
Compound 4: the middle estimate sits 1.1-fold (0.04 log units) below what was measured; low and high end bracket the measured number.
By their numbers in this assay, from the lowest: compounds 3, 2, 1 and 4 (each within the scatter of the next).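

In this assay, the exchange on the core of compound 3 gives a 1.1-fold higher number from compound 3 to compound 4 (0.04 log units; within the scatter), and the reverse exchange, five bonds along the chain from a double-bonded chain carbon, gives a 1.0-fold higher number from compound 2 to compound 4 (0.02 log units; within the scatter). The change between 2-(3,5-dihydroxyphenyl)ethyl and 3,5-dihydroxyphenyl now stands on two cores and stays within the scatter on both: the same change on two cores in this assay, a 1.1-fold lower number (0.04 log units; within the scatter) from compound 1 to compound 3 and a 1.0-fold lower number (0.02 log units; within the scatter) from compound 4 to compound 2, 1.0-fold (0.02 log units) apart, within the scatter of two such steps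

Every step shown lies within the scatter, so these compounds do not tell what, if anything, moves this number. As far as these compounds go, whether an amine or a carboxylic acid in place of a hydroxyl, or a much longer chain, would do so stays open.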